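Replacing a chain end with phenyl on the piperidine substituent

The source may report more compounds than this note shows. Statements on the series, on what has been measured and on what is new or still open speak of the compounds shown alone.

Measured so far:
compound 1 `COc1ccc2nccc(C3CN(C4CCN(Cc5cc6ccccc6n5C)CC4)C(=O)O3)c2c1` — 3160 nM
compound 2 `COc1ccc2nccc(C3CN(C4CCN(Cc5cc6ccccc6s5)CC4)C(=O)O3)c2c1` — 794 nM
compound 3 `CCCCCCN1CCC(N2CC(c3ccnc4ccc(OC)cc34)OC2=O)CC1` — 501 nM

In an in vitro functional assay on RBL cells for antagonist activity at C-C chemokine receptor type 8 (Homo sapiens), read by FLIPR and calcium flux (a lower number here means a stronger inhibitor, a higher number a weaker inhibitor), compound 3 has the lowest number of the three, but its gap to compound 2 is within the scatter, while compound 1 sits clearly higher. Compound 4 `COc1ccc2nccc(C3CN(C4CCN(CCCc5ccccc5)CC4)C(=O)O3)c2c1` differs from compound 3 by phenyl in place of propyl on a saturated chain carbon, three bonds along the chain from an amine nitrogen in a ring. Within the data shown here, the steps that bear on an aromatic ring near the ring nitrogen are a 6.3-fold lower number from compound 1 to compound 3 (0.80 log units; beyond the scatter) and a 1.6-fold lower number from compound 2 to compound 3 (0.20 log units; within the scatter); only the first lies beyond the scatter, and the new ring sits further out. Compound 4 is therefore expected to change little, a 1.3-fold higher number from compound 3 to compound 4 (0.11 log units; within the scatter). For compound 4 the estimate in this assay is 650 nM, with a range from 220 nM to 2000 nM.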

Compound 4, half-maximal inhibitory concentration: 251 nM
Estimate against measurement, compound 4: 2.6-fold (0.41 log units) above; the measured number falls inside the stated range.
By their numbers in this assay, from the lowest: compounds 4, 3 and 2 (each within the scatter of the next, the first and the last beyond it); then compound 1.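

In this assay phenyl in place of propyl on this saturated chain carbon gives a step that stays within the scatter (a 2.0-fold lower number from compound 3 to compound 4 (0.30 log units; within the scatter)), so compound 4 shows that an aromatic ring at this chain end is tolerated. Its phenethyl group also compares well with the groups of the two earlier aromatic compounds (a 3.2-fold lower number from compound 2 to compound 4 (0.50 log units; beyond the scatter); a 13-fold lower number from compound 1 to compound 4 (1.10 log units; beyond the scatter)). No measurement here explains these steps. The compounds shown leave open how a pyridine ring, a carboxylic acid or an amine at this chain end would read.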